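The source may report more compounds than this note shows. Statements on the series, on what has been measured and on what is new or still open speak of the compounds shown alone.

The compounds share one core and are read in a toxicity assay on NIH3T3 cells (Mus musculus) for cytotoxicity, read by resazurin assay; a higher number here means that more compound is needed for the effect, a lower number that less compound is needed. Compound 1 `Clc1ccc(NCc2cncn2Cc2ccc(-c3ccccc3)cc2)cc1-c1ccccc1`, which carries chloro, is reported only as a limit, > 1000 nM. Compound 2 `c1ccc(-c2ccc(Cn3cncc3CNc3cccc(-c4ccccc4)c3)cc2)cc1`, with hydrogen in place of that chloro, gives a number, 10000 nM. Compound 3 `N#Cc1ccc(NCc2cncn2Cc2ccc(-c3ccccc3)cc2)cc1-c1ccccc1`, with cyano there, is also reported only as a limit, > 1000 nM. Compound 3 therefore has no number of its own and stands at the limit of > 1000 nM in this assay, at which 2 of the 3 values shown sit.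

The step to compound 4 `O=C(c1ccc(NCc2cncn2Cc2ccc(-c3ccccc3)cc2)cc1-c1ccccc1)N1CCCCC1` puts (piperidin-1-yl)carbonyl in place of cyano on an aromatic carbon, ortho to a phenyl group and para to a large group ((piperidin-1-yl)carbonyl in place of cyano on an aromatic carbon). Within the data shown here, three measured steps bear on this change, since each swaps a group on that same carbon. They are a step that the limit leaves unreadable from compound 2 to compound 3, a step that the two limits leave unreadable from compound 1 to compound 3 and a step that the limit leaves unreadable from compound 1 to compound 2. Among the measured compounds shown here, none of them has a readable size, so they support no expected direction in this assay and no particular size of step. Compound 4 is expected to stay in the same high range because compound 2 gives 10000 nM. The expected step is a step that the limit leaves unreadable from compound 3 to compound 4. For compound 4 the estimated value is 8000 nM, with an expected range of 2000 nM to 30000 nM.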

Compound 4, half-maximal effective concentration: > 1000 nM
Compound 4 ended at the assay's limit (the forecaster's own chance of this, stated with the estimate: 60%); the middle value is on the limit's open side.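

In this assay compound 4 is reported only as a limit, > 1000 nM. Among these compounds, its steps to compound 1, compound 2 and compound 3 cannot be read, so this result yields no new step. The compounds shown leave open whether the group on that aromatic carbon changes the value at all, because most values sit at one limit: the limit of > 1000 nM in this assay, at which 3 of the 4 values shown sit.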